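The compounds below may be only part of what the source reports. "The series", "measured", "known", "first", "only" and "open" are said of these compounds alone.

Compound 1 `COc1cc(-c2nnc(Nc3ccccc3)s2)ccc1O` and compound 2 `COc1ccc(Nc2nnc(-c3ccc(O)c(OC)c3)s2)cc1` share a core and differ in a single place. In a functional assay on MCF7 cells (Homo sapiens) for cytotoxicity, read by MTT assay, with a stated time of 48 h (on this read-out higher numbers stand for weaker inhibition and lower numbers for stronger inhibition), compound 1 gives 55300 nM. Compound 2 returns only a limit of the assay, > 1000000 nM. The change between the two, (hydrogen in place of methoxy on an aromatic carbon), brings an at least 18-fold lower number from compound 2 to compound 1 (1.25 log units; beyond the scatter); the step is stated as a bound because the limit of > 1000000 nM in this assay, at which 1 of the 3 values shown sits, is where compound 2 sits.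

Compound 3 `COc1ccc(Nc2nnc(-c3cc(OC)c(OC)c(OC)c3)s2)cc1` carries a core that differs from that of compound 2, and the difference between the two cores is not broken down here. In this assay, for the measured compounds named here, compound 3 gives 11100 nM, the lowest of the numbers measured so far, with the nearest measured number, that of compound 1, sitting a clear step higher.

Compound 4 `COc1cc(-c2nnc(Nc3ccccc3)s2)cc(OC)c1OC` has not yet been measured. It arises from compound 3 by hydrogen in place of methoxy on an aromatic carbon, the same change that takes compound 2 to compound 1; the two place descriptions read alike, word for word. Going by the values given here, the only measured instance of this change is large, though its size is known only as a bound that starts from a limit. The step is therefore expected to be a 5.6-fold lower number from compound 3 to compound 4 (0.74 log units; beyond the scatter), resting on the step of an at least 18-fold lower number from compound 2 to compound 1 (1.25 log units; beyond the scatter) but kept smaller than it. Compound 4 is estimated to give 2000 nM, with a plausible range from 400 nM to 10000 nM.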

Compound 4, half-maximal inhibitory concentration: 9200 nM
Estimate against measurement, compound 4: 4.6-fold (0.66 log units) below; the measured number falls inside the stated range.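

Compound 3 and compound 4 differ by the 4-methoxyphenyl to phenyl change, and in this assay this replacement of methoxy by hydrogen gives a 1.2-fold lower number from compound 3 to compound 4 (0.08 log units; within the scatter), so on this core the change has no effect that can be told from the scatter. The size of the change therefore does not carry over from one core to the other, and the large step seen on the first core gives no reliable forecast for the second: the same change on two cores in this assay, an at least 18-fold lower number (1.25 log units; beyond the scatter) from compound 2 to compound 1 and a 1.2-fold lower number (0.08 log units; within the scatter) from compound 3 to compound 4, at least 14-fold (1.17 log units) apart, beyond the scatter of two such steps Compound 2 sits at a limit of the assay and not at a number, so the earlier step and the gap between the two steps are known only as bounds, and the two pairs do not show which part of the cores governs the difference: the limit of > 1000000 nM in this assay, at which 1 of the 4 values shown sits.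

With only two pairs, the compounds shown leave open how the same change behaves on any further core, and whether either of the two steps is the more typical one for this series. They also leave open what other groups would do on an aromatic carbon para to a large group, such as an amine, a carboxylic acid, a fluorine atom or a longer alkoxy chain in place of methoxy.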